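Moving from 4-bromophenyl to 3-bromophenyl: notes on compound 3

This account rests on a few compounds, and the source may have more. Where it says the series, first, only, none or still open, it means among the compounds named here.

Of the compounds shown here, two have been measured so far. In an ADME assay on HEK293 cells (Homo sapiens) for cytotoxicity, read by MTT assay, with a stated time of 72 h (a lower number here means a stronger inhibitor, a higher number a weaker inhibitor), compound 1 (`O=C(CN1CCN(C(=O)c2cccc(Br)c2)CC1)N1CCN(CCCc2c[nH]c3ccccc23)CC1`) gives 80700 nM and compound 2 (`COc1ccc2[nH]cc(CCCN3CCN(C(=O)CN4CCN(C(=O)c5ccc(Br)cc5)CC4)CC3)c2c1`) gives 80500 nM in the same read-out. These two values lie within the scatter of each other, so compound 2 stands level with compound 1 and no ranking can be drawn between them.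

Among the measured compounds shown here, compound 3 (`COc1ccc2[nH]cc(CCCN3CCN(C(=O)CN4CCN(C(=O)c5cccc(Br)c5)CC4)CC3)c2c1`) has no measurement yet. Set against compound 2, it differs by 3-bromophenyl in place of 4-bromophenyl on a carbonyl carbon and nothing else: 3-bromophenyl in place of 4-bromophenyl on a carbonyl carbon. For the measured compounds named here, no measured pair differs in one place only, so the data do not show directly what such a change does in this assay here. Going by the values given here, the only guide is that compound 2 at 80500 nM and compound 1 at 80700 nM show no gap beyond the scatter. The step of a 1.0-fold lower number from compound 2 to compound 3 (0.00 log units; within the scatter) is therefore expected to stay within the scatter, with no direction favoured. The estimated value for compound 3 is 80000 nM with an expected range from 45000 nM to 140000 nM in this measurement.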

Compound 3, half-maximal inhibitory concentration: 57000 nM
Beside the measured number, compound 3's estimate is 1.4-fold (0.15 log units) above it; the measured number falls inside the stated range.
By their numbers in this assay, from the lowest: compounds 3, 2 and 1 (each within the scatter of the next).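

Among the compounds shown here, these are the first single-place comparisons, and in this assay the shift of bromine on the benzoyl group gives a 1.4-fold lower number from compound 2 to compound 3 (0.15 log units; within the scatter) with the rest of the molecule unchanged, so 3-bromophenyl and 4-bromophenyl on this carbonyl carbon are not separated by this read-out. The second single-place comparison gives a 1.4-fold lower number from compound 1 to compound 3 (0.15 log units; within the scatter) for methoxy in place of hydrogen on an aromatic carbon, so within these compounds neither the bromine placement nor the methoxy group moves the number beyond the usual spread of repeat measurements. No measurement bears on why these compounds read as they do, and no cause can be assigned to either step.

Going by these compounds, both changes are small edits that keep bromine or add one methoxy, so it remains open whether an amine or a carboxylic acid in place of the bromine on the phenyl ring would shift this assay beyond the scatter. Equally open, on these data alone, is whether a longer chain in place of the propyl link to the core, or a hydroxy group in place of the methoxy, would separate any compound from this cluster.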